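The compounds below may be only part of what the source reports. "The series", "measured", "known", "first", "only" and "open" are said of these compounds alone.

Measured so far in an assay on ileum for inhibition of Voltage-dependent L-type calcium channel subunit alpha-1C (Cavia porcellus); a higher number here means a weaker inhibitor, a lower number a stronger inhibitor:
compound 1 `CCOC(=O)C1=C(C)NC(C)=C(C(=O)OCC)C1c1[nH]c(CC)nc1Cl`, 0.158 nM
compound 2 `CCc1nc(C2C(C(=O)OC)=C(C)NC(C)=C2C(=O)OCCc2ccccc2)c(Cl)[nH]1`, 0.0309 nM
compound 3 `CCc1nc(Cl)c(C2C(C(=O)OC3CCCCC3)=C(C)NC(C)=C2C(=O)OC2CCCCC2)[nH]1`, 0.132 nM

Of these three, compound 2 gives the lowest number. Compound 3 stands next, with a gap that lies beyond the usual scatter, and compound 1 stands furthest, also beyond the scatter. Compound 2 is therefore the strongest inhibitor of the three in this assay. The three compounds differ from one another at more than one place at a time, so no single gap among them can be traced to a single structural change.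

Compound 4 `CCOC(=O)C1=C(C)NC(C)=C(C(=O)OCCc2ccccc2)C1c1nc(CC)[nH]c1Cl` has not yet been measured. It differs from compound 2 in one place only: methyl in place of hydrogen on a saturated chain carbon bound to an oxygen next to a carbonyl group. Read one bond further out, this is methoxycarbonyl to ethoxycarbonyl. Among the compounds with values here, none of the measured pairs isolates this change, so the expected step rests only on how little is added. The expectation for compound 4 in this assay is a step that stays within the scatter, with no clear direction: a 1.3-fold higher number from compound 2 to compound 4 (0.11 log units; within the scatter). Compound 4 is estimated at 0.04 nM, with a range from 0.015 nM to 0.12 nM.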

Compound 4, half-maximal inhibitory concentration: 0.0457 nM
Beside the measured number, compound 4's estimate is 1.1-fold (0.06 log units) below it; the range from low to high includes it.
By their numbers in this assay, from the lowest: compounds 2 and 4 (each within the scatter of the next); then compounds 3 and 1 (each within the scatter of the next).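

In this assay, within the data shown here, the change from methoxycarbonyl to ethoxycarbonyl gives a 1.5-fold higher number from compound 2 to compound 4 (0.17 log units; within the scatter) and is the first step that can be read for a single change, namely methyl in place of hydrogen on a saturated chain carbon bound to an oxygen next to a carbonyl group. With the rest of the structure held constant, this one added methyl leaves the number within the scatter, so methoxycarbonyl and ethoxycarbonyl cannot be told apart at this position in this assay. No measurement is at hand that would account for the size of this step.

Still open, from the compounds shown here alone, is whether a longer chain such as propoxycarbonyl, a branched chain such as isopropoxycarbonyl, or a carboxylic acid at this position would also stay within the scatter of compound 2. Also open, going by these compounds, is whether the same added methyl would give a step of similar size with a different group on the other side of the shared core, as this single pair speaks for one structural setting only.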